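The compounds below may be only part of what the source reports. "The series", "measured", "known", "first", "only" and "open" are said of these compounds alone.

Working notes on the series. The shared core carries an amino group on a pyridine-like ring that is varied across the set. Compound 1 `COc1cc(Nc2ncccc2-c2n[nH]c(Nc3ccc4c(c3)OCCO4)n2)cc(OC)c1` carries 3,5-dimethoxyphenyl there; in a functional assay on A-431 cells (Homo sapiens), tested at 0.1 uM (on this read-out lower numbers stand for less inhibition and higher numbers for more inhibition at the one concentration tested (going by the name of the read-out)), compound 1 gives 83%. Compound 2 `O=C1CCCN1CCCNc1ncccc1-c1n[nH]c(Nc2ccc3c(c2)OCCO3)n1` carries a longer chain bearing a lactam; in this assay compound 2 gives "not determined" (no result reported), so no number is available for it. Compound 3 `Fc1ccc(CNc2ncccc2-c2n[nH]c(Nc3ccc4c(c3)OCCO4)n2)cc1F` carries 3,4-difluorobenzyl; in this assay compound 3 gives 32%, the lowest of the two numbers in hand, and the only shown step, a number 51 percentage points lower from compound 1 to compound 3 (beyond the scatter), is large and downward.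

Compound 4 `COc1ccc(CNc2ncccc2-c2n[nH]c(Nc3ccc4c(c3)OCCO4)n2)cc1` differs from compound 3 in one place: 4-methoxyphenyl in place of 3,4-difluorophenyl on a saturated chain carbon bound to a nitrogen on an aromatic ring. Among the compounds with values here, the one measured step changes both the linker and the ring substituents at once, so it bears only loosely on this change, which keeps the benzyl linker. Within the data shown here, no step within the benzyl series is in hand, so a step of modest size in either direction, or none beyond the scatter, is expected in this assay, a number 8 percentage points higher from compound 3 to compound 4 (within the scatter). For compound 4 the estimate in this assay is 40%, expected to fall between 18% and 65%.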

Compound 4, a percentage reported as inhibition, at one concentration (the size of the read-out at that concentration, not a potency): 30%
The estimate for compound 4 lay 10 percentage points above the measured number; low and high end bracket the measured number.
By their numbers in this assay, from the lowest: compounds 4 and 3 (each within the scatter of the next); then compound 1.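

In this assay the ring on the benzyl linker can change without a readable effect: a number 2 percentage points lower from compound 3 to compound 4 (within the scatter), so 4-methoxyphenyl and 3,4-difluorophenyl cannot be told apart at this position. The large gap to the directly attached aryl group also recurs with a second benzyl group: a number 53 percentage points lower from compound 1 to compound 4 (beyond the scatter). The low read-out therefore belongs to both 3,4-difluorobenzyl and 4-methoxybenzyl among the compounds shown, rather than to one particular set of ring substituents. No measurement at hand accounts for either step.

Still open, as far as these compounds go, is whether the loss follows the saturated chain carbon or the change of ring substituents; a 3,5-dimethoxybenzyl group on the same nitrogen would separate the two. Also open, from the compounds shown here alone, is how a benzyl ring bearing a morpholine or a carboxylic acid would read.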